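Rearranging the linker at the benzylic position of the cinnamic acid

This account rests on a few compounds, and the source may have more. Where it says the series, first, only, none or still open, it means among the compounds named here.

Three compounds share one core and differ only in the group on the saturated chain carbon bound to the aromatic carbon. Compound 1 `O=C(O)/C=C/c1ccc(Cn2ccnc2)cc1OCCc1ccc2ccccc2c1` gives 2200 nM in an assay on CHO cells for displacement of a labelled ligand from prostaglandin E2 receptor EP4 subtype (Mus musculus), read by scintillation counting; on this read-out higher numbers stand for weaker inhibition and lower numbers for stronger inhibition; compound 2 `O=C(O)/C=C/c1ccc(Cc2ccccc2)cc1OCCc1ccc2ccccc2c1` gives 2100 nM; compound 3 `O=C(O)/C=C/c1ccc(COc2ccccc2)cc1OCCc1ccc2ccccc2c1` gives 2600 nM. The number for compound 3 is the highest of the three, yet a 1.2-fold higher number from compound 1 to compound 3 (0.07 log units; within the scatter) and a 1.2-fold higher number from compound 2 to compound 3 (0.09 log units; within the scatter) both lie within the scatter, as does a 1.0-fold lower number from compound 1 to compound 2 (0.02 log units; within the scatter). Compound 4 `O=C(O)/C=C/c1ccc(OCc2ccccc2)cc1OCCc1ccc2ccccc2c1` is not yet measured; it differs from compound 3 by benzyloxy in place of phenoxymethyl on an aromatic carbon. All three measured steps concern the same position and none moved the number beyond the scatter, so a further change there that keeps the same atoms is expected to give no step beyond the scatter in this assay, in either direction. Compound 4 is therefore estimated at 2400 nM, with a range from 1200 nM to 4800 nM. The expected step from compound 3 is a 1.1-fold lower number from compound 3 to compound 4 (0.03 log units; within the scatter).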

Compound 4, inhibition constant: > 10000 nM
Compound 4: a limit, no number (the forecaster's own chance of this, stated with the estimate: 5%); middle value at least 4.1-fold (0.61 log units) away from the limit.
By their numbers in this assay, from the lowest: compounds 2, 1 and 3 (each within the scatter of the next). At a limit, above all of these: compound 4.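

In this assay, compound 4 stands at a limit of the assay and not at a number: the limit of > 10000 nM in this assay, at which 1 of the 4 values shown sits. For the compounds shown here, the position looked flat across (1H-imidazol-1-yl)methyl, benzyl and phenoxymethyl, but with the same atoms joined differently the change gives an at least 3.8-fold higher number from compound 3 to compound 4 (0.58 log units; beyond the scatter), the first step at this position beyond the scatter. The other two comparisons agree, with an at least 4.7-fold higher number from compound 2 to compound 4 (0.67 log units; beyond the scatter) and an at least 4.5-fold higher number from compound 1 to compound 4 (0.65 log units; beyond the scatter), so the group on this aromatic carbon matters once benzyloxy enters, and how its atoms are joined counts, not just which atoms are present.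

The compounds shown leave open whether this step belongs to the oxygen bound to the aromatic carbon or to benzyloxy as a whole. An amine in place of that oxygen, or a longer chain between oxygen and phenyl, would separate the two readings.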